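The source may hold more compounds than are shown below. What is called first, only, known or untested is meant among the compounds shown, and "the series" means these compounds.

Notes on the series, all sharing one core and differing in the group on the oxygen. In a functional assay on NCI-H23 cells (Homo sapiens) for antiproliferative activity, read by sulforhodamine B assay (on this read-out higher numbers stand for weaker inhibition of growth and lower numbers for stronger inhibition of growth), compound 1 `CCCCOc1cccc(O)c1C(=O)/C=C/c1ccc(O)cc1` gives > 30000 nM, which is a limit of the assay and not a number. Compound 2 `CCC(CC)COc1cccc(O)c1C(=O)/C=C/c1ccc(O)cc1` gives 3210 nM, and compound 3 `CC(C)COc1cccc(O)c1C(=O)/C=C/c1ccc(O)cc1` gives 3220 nM. For the measured compounds named here, these are the only two numbers so far, and they lie within the scatter of each other, so compound 3 shares its place on the scale with compound 2.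

The next change leads to compound 4 `O=C(/C=C/c1ccc(O)cc1)c1c(O)cccc1OCc1ccccc1`: phenyl in place of isopropyl on a saturated chain carbon bound to an oxygen on an aromatic ring. Cut one bond further out, this reads isobutoxy to benzyloxy.

Two kinds of measured step bear on it. The steps of an at least 9.3-fold lower number from compound 1 to compound 2 (0.97 log units; beyond the scatter) and an at least 9.3-fold lower number from compound 1 to compound 3 (0.96 log units; beyond the scatter) are both beyond the scatter, and both are set against a limit. The closest guide is a 1.0-fold higher number from compound 2 to compound 3 (0.00 log units; within the scatter), a swap of the group at this same place that stays within the scatter. Going by the values given here, no measured compound carries a ring at this place, so the guide is weak.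

The expected outcome is a 1.2-fold higher number from compound 3 to compound 4 (0.09 log units; within the scatter), a step no larger than the scatter in either direction, although a limit as for compound 1 remains possible. For compound 4 the estimated value is 4000 nM, with an expected range of 1200 nM to 15000 nM.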

Compound 4, concentration for 50% growth inhibition: > 30000 nM
Compound 4 was reported as a limit; the forecaster's own chance of this, stated with the estimate: 15%; middle value at least 7.5-fold (0.87 log units) away from the limit.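

In this assay, phenyl in place of isopropyl gives an at least 9.3-fold higher number from compound 3 to compound 4 (0.96 log units; beyond the scatter), and phenyl in place of pentan-3-yl gives an at least 9.3-fold higher number from compound 2 to compound 4 (0.97 log units; beyond the scatter), so at this place on a saturated chain carbon bound to an oxygen on an aromatic ring, the swap between the two branched groups stayed within the scatter while the entry of a six-membered aromatic ring does not. Before this, compound 1 was the only member of the series without a measurable number; compound 4 shows that a second, quite different group gives the same outcome, so the read-out at this place depends on the group, and among the compounds shown only compound 2 and compound 3 give numbers. Compound 4 is reported as a limit of the assay and not a number: the limit of > 30000 nM in this assay, at which 2 of the 4 values shown sit.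

The two limits leave the step between compound 1 and compound 4 unreadable, so these two cannot be ordered. Also open, on these data alone, is whether a phenethyl group, a benzyl carrying a methoxy group or a chain ending in an amine would fall near compound 2 and compound 3 or at the limit.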